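This account rests on a few compounds, and the source may have more. Where it says the series, first, only, none or still open, it means among the compounds named here.

Working notes on the series. Among the measured compounds shown here, in a functional assay on HL-60 cells (Homo sapiens) for inhibition, with a stated time of 72 h (a higher number here means a weaker inhibitor of growth, a lower number a stronger inhibitor of growth), compound 1 (`CCN(CC)S(=O)(=O)c1ccc(OC)c(NC(=O)c2[nH]c(C)c3c2CCCCC3=O)c1`) gives 1360 nM, the lower of the two actual numbers so far. Compound 2 (`CCc1c(C(=O)Nc2cc(S(=O)(=O)N(CC)CC)ccc2O)[nH]c(C)c1C(C)=O`) gives 17000 nM, and that gap lies beyond the scatter. Compound 3 (`CCN(CC)S(=O)(=O)c1ccc(O)c(NC(=O)c2[nH]c(C)c3c2CCCCC3=O)c1`) reads > 40000 nM, which is a limit of this assay and not a number.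

The next compound to be measured is compound 4 (`COc1ccc(S(=O)(=O)N2CCCCCC2)cc1NC(=O)c1[nH]c(C)c2c1CCCCC2=O`). It differs from compound 1 in one place: azepan-1-yl in place of diethylamino on a sulfonyl sulfur. In words, azepan-1-yl stands in place of diethylamino on a sulfonyl sulfur.

For the measured compounds named here, only one measured step exists, an at least 29-fold higher number from compound 1 to compound 3 (1.46 log units; beyond the scatter). It is large, but it concerns hydrogen in place of methyl on an oxygen on an aromatic ring, a different change from the one at hand. Going by the values given here, no measured step touches the group on the sulfonyl sulfur, so that large step is not carried over. The expectation therefore starts from compound 1 at 1360 nM, with no step beyond the scatter expected in this assay in either direction. The estimated step is a 1.0-fold lower number from compound 1 to compound 4 (0.02 log units; within the scatter). For compound 4 the estimated value is 1300 nM, with an expected range from 450 nM to 4000 nM.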

Compound 4, concentration for 50% growth inhibition: 565 nM
Beside the measured number, compound 4's estimate is 2.3-fold (0.36 log units) above it; low and high end bracket the measured number.
By their numbers in this assay, from the lowest: compound 4; then compound 1; then compound 2. At a limit, above all of these: compound 3.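

In this assay, the group on the sulfonyl sulfur now proves able to shift the read-out: azepan-1-yl in place of diethylamino gives a 2.4-fold lower number from compound 1 to compound 4 (0.38 log units; beyond the scatter). Among the compounds shown here, this is the first measured step at this position, since the earlier compounds all carried diethylamino there, and it is modest but runs towards stronger inhibition of growth. For the compounds shown here, the position therefore accepts a seven-membered non-aromatic ring in place of the open diethylamino group on the core of compound 1 without loss in this assay, and the only other measured step, on the oxygen, remains a separate change.

As far as these compounds go, the change adds a ring and further carbon together, so whether either alone carries the step stays open, as does the outcome with piperidin-1-yl, morpholin-4-yl or an open dipropylamino group on the sulfonyl sulfur. Whether the step holds with hydrogen in place of methyl on the oxygen also stays open, as compound 3 gives only a limit and not a number: the limit of > 40000 nM in this assay, at which 1 of the 4 values shown sits.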